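A few compounds are considered here, and "the series" means these few. Any claim that something is new, unique, unknown or untested is made for them only; others in the source may bear on it.

Compound 1 `COc1ccc(-c2ccnc(Nc3ccc([N+](=O)[O-])cc3)n2)cc1` and compound 2 `O=[N+]([O-])c1ccc(Nc2nccc(-c3ccc(F)cc3)n2)cc1` share one core and differ only in the small group attached to its outer ring. In an assay on isolated protein for inhibition of phosphatidylinositol 4,5-bisphosphate 3-kinase catalytic subunit beta isoform (Homo sapiens) (on this read-out lower numbers stand for stronger inhibition and higher numbers for weaker inhibition), compound 1 gives 537 nM, and compound 2 gives 863 nM. Among the compounds with values here, the change between them, a 1.6-fold higher number from compound 1 to compound 2 (0.21 log units; within the scatter), is too small to be read as a real difference, so on the numbers known compound 2 stands alongside compound 1, the only other measured compound, and the two cannot be told apart.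

Compound 3 `O=[N+]([O-])c1ccc(Nc2nccc(-c3ccc(Cl)c(Cl)c3)n2)cc1` has not been measured. It differs from compound 2 in one place: 3,4-dichlorophenyl in place of 4-fluorophenyl on an aromatic carbon. Within the data shown here, no measured step exchanges a fluorine for chlorine or adds a second halogen; the only comparable step, the exchange of one small substituent on that same ring from compound 1 to compound 2, stayed within the scatter. On that basis the step of a 1.2-fold lower number from compound 2 to compound 3 (0.09 log units; within the scatter) is expected to be small in this assay, in no particular direction. Compound 3 is therefore expected to give about 700 nM, with a plausible range from 250 nM to 2000 nM.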

Compound 3, half-maximal inhibitory concentration: 573 nM
The estimate for compound 3 lay 1.2-fold (0.09 log units) above the measured number; the range from low to high includes it.
By their numbers in this assay, from the lowest: compounds 1, 3 and 2 (each within the scatter of the next).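

In this assay, replacing the 4-fluorophenyl group with 3,4-dichlorophenyl gives only a small shift (a 1.5-fold lower number from compound 2 to compound 3 (0.18 log units; within the scatter)), and replacing the 4-methoxyphenyl group of compound 1 with the same ring gives another (a 1.1-fold higher number from compound 1 to compound 3 (0.03 log units; within the scatter)). Within the data shown here, the earlier pair showed only that one small group on this outer ring could be exchanged for another without a readable difference; compound 3 extends that to a ring carrying two chlorines, one more heavy atom than the 4-fluorophenyl group it replaces, and the three compounds still cannot be told apart at this position. No independent evidence bears on why these three rings read alike.

Going by these compounds, all three outer rings are phenyl rings carrying only halogens or a methoxy group, so it remains open whether an amine, a carboxylic acid or a longer chain such as butoxy on that ring would move the number beyond the scatter. On these data alone, the nitro group on the other ring is the same in all three compounds, so what an amide or a nitrile in its place would do is also open.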